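A Larger Aryl Group on the Ring Nitrogen

A few compounds are considered here, and "the series" means these few. Any claim that something is new, unique, unknown or untested is made for them only; others in the source may bear on it.

Compound 1, `CC(C)[C@@H]1CC[C@@H](C)C[C@@]12N(C)C(=O)[C@@H]1[C@H]3C(=O)NC(=O)[C@H]3ON12`, gives 72% in a functional assay, read by spectrophotometry, with a stated time of 2 h, tested at 3 mg/mL; on this read-out higher numbers stand for a stronger effect at the one concentration tested and lower numbers for a weaker effect.
Compound 2, `CC(C)[C@@H]1CC[C@@H](C)C[C@@]12N(C)C(=O)[C@@H]1[C@H]3C(=O)N(c4ccccc4)C(=O)[C@H]3ON12`, gives 73.5%.
Compound 3, `Cc1ccc(N2C(=O)[C@H]3[C@H](ON4[C@@H]3C(=O)N(C)[C@@]43C[C@H](C)CC[C@H]3C(C)C)C2=O)c(C)c1`, gives 85.8%.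

Compound 3 gives the highest of the three numbers, and its margins over compound 2 and over compound 1 are both beyond the scatter, so it stands clearly at the top. Compound 4, `CC(C)[C@@H]1CC[C@@H](C)C[C@@]12N(C)C(=O)[C@@H]1[C@H]3C(=O)N(c4ccc5ccccc5c4)C(=O)[C@H]3ON12`, has not yet been measured. The change is naphthalen-2-yl in place of 2,4-dimethylphenyl on an amide-type nitrogen in a ring.

Within the data shown here, three measured steps concern the same ring nitrogen. a number 1.5 percentage points higher from compound 1 to compound 2 (within the scatter) shows that phenyl in place of hydrogen changed little. a number 13.8 percentage points higher from compound 1 to compound 3 (beyond the scatter) and a number 12.3 percentage points higher from compound 2 to compound 3 (beyond the scatter) show that 2,4-dimethylphenyl brought a modest gain. Among the measured compounds shown here, no measured step brings in a second aromatic ring, so there is no direct guide for naphthalen-2-yl. With one neutral and one modestly positive step behind it, a small fall or a number within the scatter of compound 3 is expected, a number 5.8 percentage points lower from compound 3 to compound 4 (within the scatter). Compound 4 is therefore estimated at 80%, between 65% and 93%.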

Compound 4, a percentage reported as activity, at one concentration (the size of the read-out at that concentration, not a potency): 60.1%
For compound 4 the middle estimate is 19.9 percentage points above the measured one, outside the stated range (below it).
By their numbers in this assay, from the lowest: compound 4; then compounds 1 and 2 (each within the scatter of the next); then compound 3.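

In this assay the change to naphthalen-2-yl on this ring nitrogen gives a number 25.7 percentage points lower from compound 3 to compound 4 (beyond the scatter) together with a number 13.4 percentage points lower from compound 2 to compound 4 (beyond the scatter) and a number 11.9 percentage points lower from compound 1 to compound 4 (beyond the scatter) so this position can lose ground as well as hold or gain it, and the second aromatic ring leaves compound 4 behind even the compound with only hydrogen there. More carbon in the group on this nitrogen went with a higher number in compound 3 but a lower one in compound 4, so carbon count alone does not order these compounds. Nothing measured here accounts for the fall.

Still open, from the compounds shown here alone, is whether one methyl alone, as in 2-methylphenyl or 4-methylphenyl, would match 2,4-dimethylphenyl. Also open, going by these compounds, is how a pyridine ring or a benzyl group would fare at this nitrogen.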